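From 4-bromophenyl to 3,4-dichlorophenyl on a shared core

The source may hold more compounds than are shown below. What is called first, only, known or untested is meant among the compounds shown, and "the series" means these compounds.

In a functional assay on MCF7 cells (Homo sapiens) for cytotoxicity, read by MTT assay, with a stated time of 48 h (a higher number here means a weaker inhibitor, a lower number a stronger inhibitor), compound 1 (`CCN(CC)C(=S)SC(CC(=O)c1ccccc1)c1ccccc1`) gives 17000 nM. Compound 2 (`CCN(CC)C(=S)SC(CC(=O)c1ccc(OC)cc1)c1ccccc1`) gives 4500 nM, and compound 3 (`CCN(CC)C(=S)SC(CC(=O)c1ccc(Br)cc1)c1ccccc1`) gives 5000 nM. Two steps fix the standing of that last number: a 1.1-fold higher number from compound 2 to compound 3 (0.05 log units; within the scatter), and a 3.4-fold lower number from compound 1 to compound 3 (0.53 log units; beyond the scatter). It is thus level with its nearest neighbour and clear of the furthest.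

Compound 4 (`CCN(CC)C(=S)SC(CC(=O)c1ccc(Cl)c(Cl)c1)c1ccccc1`) has not yet been measured. Its structural change is 3,4-dichlorophenyl in place of 4-bromophenyl on a carbonyl carbon. Among the compounds with values here, no measured step makes this exact change, and no chloro compound has a value yet. The closest evidence comes from the two substituents already tried on this aromatic ring. One is a 3.8-fold lower number from compound 1 to compound 2 (0.58 log units; beyond the scatter), and the other is the bromo step already given, of similar modest size. Exchanging one substituent for the other moved the number by no more than the scatter, so the series offers no sign yet of a large shift between substituted compounds.

In this assay the expected size of the move is a 1.3-fold lower number from compound 3 to compound 4 (0.10 log units; within the scatter), so no step beyond the scatter is anticipated. For compound 4 the estimate is 4000 nM, with an expected range from 1700 nM to 9500 nM.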

Compound 4, half-maximal inhibitory concentration: 4500 nM
The estimate for compound 4 lay 1.1-fold (0.05 log units) below the measured number, and the stated range covers the measured number.
By their numbers in this assay, from the lowest: compounds 2, 4 and 3 (each within the scatter of the next); then compound 1.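

In this assay, the 3,4-dichlorophenyl group on the carbonyl carbon joins the level already held by the two singly substituted rings: the result is a 1.1-fold lower number from compound 3 to compound 4 (0.05 log units; within the scatter), and no change at the digits printed from compound 2 to compound 4 (within the scatter), while against the plain phenyl ring there is a 3.8-fold lower number from compound 1 to compound 4 (0.58 log units; beyond the scatter). This position has now taken three different substituted rings, including the first with two chlorine atoms and the first with a larger count of heavy atoms than 4-bromophenyl, and among the compounds shown all three stand clear of compound 1, with none going against that pattern and no separation among the three. What lies behind this shared level cannot be said, as nothing measured here bears on a reason for it.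

On these data alone, it remains open whether a ring carrying an amine or a carboxylic acid would stay at this level, and whether a single chloro group would match the 3,4-dichlorophenyl group. Also open is whether the level would hold with a longer chain elsewhere on the shared core, since every compound shown varies only this one ring.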